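Changing the amide side chain of a hepatoma cell inhibitor

The source may hold more compounds than are shown below. What is called first, only, known or untested is meant among the compounds shown, and "the series" means these compounds.

Going by the values given here, compound 1 `CCn1c(C(=O)NCCN(C)C)ccc1C(CC)(CC)c1ccc(OCCC(O)(CC)CC)c(C)c1` is the only member of this small set to give a number in a functional assay on HepG2 cells (Homo sapiens) for antiproliferative activity, read by MTT assay, with a stated time of 48 h; a higher number here means a weaker inhibitor, a lower number a stronger inhibitor: compound 1 gives 240 nM. Compound 2 `CCn1c(C(=O)NCC#N)ccc1C(CC)(CC)c1ccc(OCCC(O)(CC)CC)c(C)c1` reaches only the limit of the assay, with > 50000 nM. Compound 3 `CCC(C)C(NC(=O)c1ccc(C(CC)(CC)c2ccc(OCCC(O)(CC)CC)c(C)c2)n1CC)C(=O)OC` likewise sits at the limit, with > 50000 nM. The step of an at least 200-fold higher number from compound 1 to compound 2 (2.31 log units; beyond the scatter) is therefore a large loss, and the step of an at least 200-fold higher number from compound 1 to compound 3 (2.31 log units; beyond the scatter) a loss of the same order; in both cases the changed compound ends at the limit of > 50000 nM in this assay, at which 2 of the 3 values shown sit. The pair of compound 2 and compound 3 shows two limits and nothing more. Compound 4 `CCn1c(C(=O)N(C)CCO)ccc1C(CC)(CC)c1ccc(OCCC(O)(CC)CC)c(C)c1` has not been measured. It differs from compound 1 in the same region of the molecule: (2-hydroxyethyl)(methyl)amino in place of (2-(dimethylamino)ethyl)amino on a carbonyl carbon. Both measured changes on the amide-type nitrogen of compound 1 led to the limit of the assay, so a large loss in this assay is expected for compound 4 as well, although whether the number stays readable is uncertain. Compound 4 is accordingly estimated at 15000 nM, with an expected range from 2500 nM to 50000 nM. This estimate means an expected 63-fold higher number from compound 1 to compound 4 (1.80 log units; beyond the scatter).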

Compound 4, half-maximal inhibitory concentration: 510 nM
Beside the measured number, compound 4's estimate is 29-fold (1.47 log units) above it, outside the stated range (below it).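

Compound 4 shows that this position on the carbonyl carbon can change without the number being lost in this assay: exchanging (2-(dimethylamino)ethyl)amino for (2-hydroxyethyl)(methyl)amino gives only a 2.1-fold higher number from compound 1 to compound 4 (0.33 log units; beyond the scatter). The dimethylamino end of compound 1 is therefore not needed for a readable number here, and a change in this side chain does not in itself lead to the loss seen with compound 2 and compound 3. The same position separates the compounds widely, with an at least 98-fold lower number from compound 3 to compound 4 (1.99 log units; beyond the scatter) and an at least 98-fold lower number from compound 2 to compound 4 (1.99 log units; beyond the scatter), and these two steps rest on limits of the assay rather than on numbers: the limit of > 50000 nM in this assay, at which 2 of the 4 values shown sit.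

The compounds shown do not separate the hydroxyl group from the methyl group on the amide-type nitrogen, as the two enter together in compound 4. As far as these compounds go, how a plain (2-hydroxyethyl)amino group, a longer chain ending in an amine, or a carboxylic acid at the end of the chain would read on this carbonyl carbon remains open.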